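This account rests on a few compounds, and the source may have more. Where it says the series, first, only, none or still open, it means among the compounds named here.

Measured so far:
compound 1 `COc1cc2c(cc1OC)C(CC(N)=O)CC2` gives 18.8%
compound 2 `CCNC(=O)CC1CCc2cc(OC)c(OC)cc21` gives 15.6%
compound 3 `COc1cc2c(cc1OC)C(CC(=O)NCc1ccccc1)CC2` gives 18.8%

In a functional assay on the whole organism (strain Wistar) for inhibition, with Rattus norvegicus as the target, read by paw edema, with stated times of 60 min and 1 h, at a dose of 100 mg/kg by the oral route (on this read-out lower numbers stand for less inhibition and higher numbers for more inhibition at the one dose given (going by the name of the read-out)), compound 1 gives 18.8%, which is level with compound 3 at the digits printed, and the two together are the highest of the three numbers; compound 2 is the furthest from compound 1, yet still within the scatter of it.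

The step considered here leads from compound 1 to the unmeasured compound 4 `COc1cc2c(cc1OC)C(CC(=O)N1CCOCC1)CC2`, whose change from compound 1 is morpholin-4-yl in place of amino on a carbonyl carbon. For the measured compounds named here, two measured steps bear on it, since both alter the amide nitrogen of compound 1: ethyl in place of hydrogen gave a number 3.2 percentage points lower from compound 1 to compound 2 (within the scatter), and benzyl in place of hydrogen gave no change at the digits printed from compound 1 to compound 3 (within the scatter). Between the two substituted amides, phenyl in place of methyl gave a number 3.2 percentage points higher from compound 2 to compound 3 (within the scatter). None of these moved the read-out beyond the scatter, so replacing the amino group by morpholin-4-yl is not expected to move it either.

On this basis compound 4 is expected to show a number 1.8 percentage points lower from compound 1 to compound 4 (within the scatter) in this assay, with an estimated value of 17% and a range from 8% to 26%.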

Compound 4, a percentage reported as inhibition, in the whole organism at one dose (the size of the read-out at that dose, not a potency): 15.6%
Estimate against measurement, compound 4: 1.4 percentage points above, and the stated range covers the measured number.
By their numbers in this assay, from the lowest: compounds 2, 4, 1 and 3 (each within the scatter of the next).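

In this assay, morpholin-4-yl on the carbonyl carbon takes away the hydrogen-bond donor of the amino group and brings in a six-membered non-aromatic ring, and the read-out still stays within the scatter (a number 3.2 percentage points lower from compound 1 to compound 4 (within the scatter)). The earlier compounds shown here all kept a hydrogen-bond donor on the amide-type nitrogen, so the new compound extends the flat picture to a ring that has none, as it also lies within the scatter of both substituted amides (a number 3.2 percentage points lower from compound 3 to compound 4 (within the scatter); no change at the digits printed from compound 2 to compound 4 (within the scatter)). No measurement is at hand that could explain this lack of separation among the four compounds.

The four compounds therefore show no group at this position that separates from the others at this one dose, and they give no sign of what on the amide nitrogen, if anything, governs the read-out. Going by these compounds, whether a piperazine ring, a longer chain on the nitrogen or a carboxylic acid in place of the amide on the chain carbon would leave the scatter remains open, as does any change to the two methoxy groups of the shared core.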